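Lengthening the chain of compound 3 by a methyl

The compounds below may be only part of what the source reports. "The series", "measured", "known", "first", "only" and "open" are said of these compounds alone.

Four compounds share one core and differ in the length of a saturated chain: compound 1 `CCCCCCC(CCO)n1cnc2c(OC)ncnc21`, compound 2 `CCCCCCCCC(CCO)n1cnc2c(OC)ncnc21`, compound 3 `CCCCCCCCCCC(CCO)n1cnc2c(OC)ncnc21` and compound 4 `CCCCCCCCCCCC(CCO)n1cnc2c(OC)ncnc21`. In a functional assay on SW480 cells (Homo sapiens) for antiproliferative activity, read by MTT assay, with a stated time of 48 h (on this read-out higher numbers stand for weaker inhibition and lower numbers for stronger inhibition), compound 1 gives > 50000 nM, which is a limit of the assay and not a number. In this assay, compound 2 gives 24600 nM. For the measured compounds named here, compound 3 gives 8260 nM, the lowest number so far, and so the strongest inhibition of the three measured compounds.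

The change to compound 4 is methyl in place of hydrogen on a saturated chain carbon, ten or more bonds along the chain from an aromatic nitrogen. All three measured steps lengthen this same chain and point in one direction. The closest guide is a 3.0-fold lower number from compound 2 to compound 3 (0.47 log units; beyond the scatter), made by ethyl in place of hydrogen. The longer reach, an at least 6.0-fold lower number from compound 1 to compound 3 (0.78 log units; beyond the scatter), made by butyl in place of hydrogen, agrees in direction, while an at least 2.0-fold lower number from compound 1 to compound 2 (0.30 log units; that floor lies within the scatter) adds little, as its floor lies within the scatter. Methyl is a smaller addition than ethyl, so a smaller step in the same direction is expected, probably not clearly beyond the scatter. Nothing measured shows whether the trend holds beyond compound 3. The estimated step is a 1.4-fold lower number from compound 3 to compound 4 (0.16 log units; within the scatter). Compound 4 is expected at 5700 nM, with an estimated range of 2500 nM to 13000 nM.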

Compound 4, half-maximal inhibitory concentration: 9700 nM
Compound 4: the middle estimate sits 1.7-fold (0.23 log units) below what was measured; low and high end bracket the measured number.
By their numbers in this assay, from the lowest: compounds 3 and 4 (each within the scatter of the next); then compound 2. At a limit, above all of these: compound 1.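

In this assay, for the compounds shown here, methyl at this place brings no change that can be read, with a 1.2-fold higher number from compound 3 to compound 4 (0.07 log units; within the scatter), so the run of lower numbers that had followed each lengthening up to compound 3 does not continue at compound 4, the one compound that goes against that pattern. Compound 4 nonetheless stays clear of the shorter chains, with a 2.5-fold lower number from compound 2 to compound 4 (0.40 log units; beyond the scatter) and an at least 5.1-fold lower number from compound 1 to compound 4 (0.71 log units; beyond the scatter), which suggests that among these four compounds the benefit of lengthening is kept at compound 4 without growing any further. For compound 1 the reference is a limit of the assay and not a number, so the second of those two steps gives only a floor: the limit of > 50000 nM in this assay, at which 1 of the 4 values shown sits.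

The compounds shown leave open whether a longer chain than that of compound 4 would hold level with compounds 3 and 4 or give a higher number again, so it cannot be said whether these two mark a plateau or a turning point. They also leave open how this assay would read if an amine or a carboxylic acid were placed at the far end of the chain, since every chain shown is a plain saturated one.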